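The compounds below may be only part of what the source reports. "The series", "measured", "known", "first", "only" and "open" are said of these compounds alone.

Measured so far:
- compound 1, `COc1cccc(NC(=O)CSc2nc(Nc3ccccc3)c3ccccc3n2)c1`: 10000 nM
- compound 2, `C=CC(=O)Nc1cccc(NC(=O)CSc2nc(Nc3cccc(Br)c3)c3ccccc3n2)c1`: 11900 nM

Both compounds were read in a functional assay on MGC-803 cells (Homo sapiens) for inhibition, read by MTT assay, with a stated time of 72 h; on this read-out higher numbers stand for weaker inhibition and lower numbers for stronger inhibition. Compound 1 gives 10000 nM there and compound 2 gives 11900 nM; the two numbers lie within the usual scatter of each other, so compound 2 does not stand apart from compound 1 on this read-out. Among the compounds with values here, no step between measured compounds is available.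

Compound 3, `C=CC(=O)Nc1cccc(NC(=O)CSc2nc(Nc3ccc(Cl)c(Cl)c3)c3ccccc3n2)c1`, is not yet measured. Its change from compound 2 is 3,4-dichlorophenyl in place of 3-bromophenyl on a nitrogen on an aromatic ring, with 3,4-dichlorophenyl entering where 3-bromophenyl leaves, on a nitrogen on an aromatic ring whose other neighbours are aromatic carbon.

With nothing in the measured pair to lean on, the expected step is none beyond the scatter, a 1.2-fold lower number from compound 2 to compound 3 (0.08 log units; within the scatter). Compound 3 is therefore estimated at 10000 nM, within 4000 nM to 30000 nM.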

Compound 3, half-maximal inhibitory concentration: > 50000 nM
Compound 3: only a limit was reported; the forecaster's own chance of this, stated with the estimate: 30%; middle value at least 5.0-fold (0.69 log units) away from the limit.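

In this assay, the group on this nitrogen proves able to move the read-out: 3,4-dichlorophenyl in place of 3-bromophenyl gives an at least 4.2-fold higher number from compound 2 to compound 3 (0.62 log units; beyond the scatter). Within the data shown here, this is the first step that changes one place only, and it runs towards weaker inhibition. Compound 3 gives > 50000 nM, a limit of the assay and not a number, so the step has a floor but no measured size: the limit of > 50000 nM in this assay, at which 1 of the 3 values shown sits.

Among these compounds, the single step does not separate the swap of bromine for chlorine from the gain of a second halogen, and 3-chlorophenyl or 4-chlorophenyl on the same nitrogen would be needed to part the two. Also open, from the compounds shown here alone, is how this nitrogen's phenyl ring behaves with a non-halogen group on it, such as a methoxy, an amine or a carboxylic acid.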